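A few compounds are considered here, and "the series" means these few. Any claim that something is new, unique, unknown or untested is made for them only; others in the source may bear on it.

Compound 1 `CC(=O)Nc1ccc2oc(-c3ccc(C(F)(F)F)cc3)cc(=O)c2c1` and compound 2 `COc1c(-c2ccc(C(F)(F)F)cc2)oc2ccc(NC(C)=O)cc2c1=O` share one core and are both tested in an ADME assay on MT4 cells (Homo sapiens) for cytotoxicity, read by MTT assay, with a stated time of 4 days; on this read-out higher numbers stand for lower toxicity in this test and lower numbers for higher toxicity in this test. In this assay compound 1 gives 330000 nM, and compound 2 gives 332000 nM. Among the compounds with values here, the single change between them is methoxy in place of hydrogen on an aromatic carbon, and it made a 1.0-fold higher number from compound 1 to compound 2 (0.00 log units; within the scatter). Compound 3 `COc1c(-c2ccccc2)oc2ccc(N)cc2c1=O` carries a different core; the difference between the two cores is not broken down here. In this assay compound 3 gives 126000 nM, the lowest of the three numbers. Compound 4 `COc1cccc(-c2oc3ccc(N)cc3c(=O)c2OC)c1` has not yet been measured in this assay. It differs from compound 3 by methoxy in place of hydrogen on an aromatic carbon. Within the data shown here, this is the same kind of change as the one from compound 1 to compound 2, but not the same: there the methoxy entered on a six-membered aromatic ring with one oxygen, part of a fused system of two rings, ortho to a group of one heavy atom and ortho to a large group, whereas here it enters on a six-membered aromatic ring of carbon only, meta to a large group. Because the earlier methoxy entry gave a 1.0-fold higher number from compound 1 to compound 2 (0.00 log units; within the scatter), a similarly small step is expected here, no change at the digits printed from compound 3 to compound 4 (within the scatter). Compound 4 is therefore estimated to give 126000 nM in this assay, most likely between 60000 nM and 260000 nM.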

Compound 4, half-maximal cytotoxic concentration: 251000 nM
Estimate against measurement, compound 4: 2.0-fold (0.30 log units) below, and the stated range covers the measured number.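

In this assay, methoxy in place of hydrogen on an aromatic carbon of the six-membered ring of carbon only, meta to a large group, made a 2.0-fold higher number from compound 3 to compound 4 (0.30 log units; within the scatter). Set beside the earlier methoxy entry on a different core and a different ring, this step cannot be told apart from it, so in these two pairs the change carries from one core to the other without a distinguishable difference: the same change on two cores in this assay, a 1.0-fold higher number (0.00 log units; within the scatter) from compound 1 to compound 2 and a 2.0-fold higher number (0.30 log units; within the scatter) from compound 3 to compound 4, 2.0-fold (0.30 log units) apart, within the scatter of two such steps This rests on only two pairs, in which both the core and the place of the methoxy differ, so it does not show that the change would behave alike on further cores or that either factor alone leaves the number unmoved.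

As far as these compounds go, whether a longer chain such as ethoxy, or a hydroxyl or an amine, entering at the same place would also stay within the scatter remains open. The compounds shown also leave open what a methoxy would do at another place on that ring.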